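Hydrazone series: aryl swap at the imine carbon

The source may hold more compounds than are shown below. What is called first, only, known or untested is meant among the compounds shown, and "the series" means these compounds.

Measured compounds in an ADME assay on THP-1 cells (Homo sapiens) for cytotoxicity; on this read-out higher numbers stand for weaker inhibition and lower numbers for stronger inhibition:
- compound 1 `COc1ccccc1-c1nnc(-c2ccc(C(=O)N/N=C/c3ccncc3)cc2)o1`, 173000 nM
- compound 2 `COc1ccccc1-c1nnc(-c2ccc(C(=O)N/N=C/c3ccc([N+](=O)[O-])cc3)cc2)o1`, 203000 nM

Compound 2 gives the higher of the two numbers, but the step between them is a 1.2-fold higher number from compound 1 to compound 2 (0.07 log units; within the scatter), so the two stand level. The next compound is compound 3 `COc1ccc(/C=N/NC(=O)c2ccc(-c3nnc(-c4ccccc4OC)o3)cc2)cc1O`, which differs from compound 2 as follows: 3-hydroxy-4-methoxyphenyl in place of 4-nitrophenyl on a carbon with a double bond to nitrogen. Going by the values given here, the only step at hand, from compound 1 to compound 2, also swapped the aryl on this carbon and stayed within the scatter. No step beyond the scatter is therefore expected in this assay. Compound 3 is estimated at 185000 nM, between 90000 nM and 380000 nM. The expected step is a 1.1-fold lower number from compound 2 to compound 3 (0.04 log units; within the scatter).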

Compound 3, half-maximal inhibitory concentration: 260000 nM
Compound 3: the middle estimate sits 1.4-fold (0.15 log units) below what was measured, within the range that was stated.
By their numbers in this assay, from the lowest: compounds 1, 2 and 3 (each within the scatter of the next).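

In this assay, the swap to 3-hydroxy-4-methoxyphenyl gives a 1.3-fold higher number from compound 2 to compound 3 (0.11 log units; within the scatter) and a 1.5-fold higher number from compound 1 to compound 3 (0.18 log units; within the scatter), so all three aryl groups on this carbon stand level. This holds even though the entering group counts 1 hydrogen-bond donor and the leaving 4-nitrophenyl counts 0. Nothing available explains this flat result.

Still open, on these data alone, is whether a cyclohexyl group in place of the aryl, or a carboxylic acid or an amine on it, would give a step beyond the scatter. The compounds shown also leave open whether any change outside this position would do so.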